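Vero cytotoxicity in a small anilide series

The source may report more compounds than this note shows. Statements on the series, on what has been measured and on what is new or still open speak of the compounds shown alone.

Compound 1 `O=c1[nH]c(Nc2cccc(O)c2)nc2cc(Cl)ccc12`: > 25000 nM
Compound 2 `N#Cc1cccc(Nc2nc3cc(Cl)ccc3c(=O)[nH]2)c1`: > 25000 nM

Both measured compounds were run in an ADME assay on Vero cells (Chlorocebus sabaeus) for cytotoxicity, read by WST assay; a lower number here means that less compound is tolerated, a higher number that more compound is tolerated. Compound 1 reaches only a limit of the assay there, > 25000 nM. Compound 2 likewise reaches only a limit, > 25000 nM. Among the compounds with values here, the single measured step, a step that the two limits leave unreadable from compound 1 to compound 2, is therefore not readable, because both values sit at the same limit (the limit of > 25000 nM in this assay, at which 2 of the 2 values shown sit). Compound 2 thus stands at that limit, with no number of its own.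

Compound 3 `O=c1[nH]c(Nc2cccc(C(F)(F)F)c2)nc2cc(Cl)ccc12` has not yet been measured. It differs from compound 2 in one place: trifluoromethyl in place of cyano on an aromatic carbon. Within the data shown here, the one measured step bears on it only by showing that neither earlier substituent brought cytotoxicity into the readable range; no size or direction can be drawn from it. Compound 3 is therefore expected to give 30000 nM, within 15000 nM and 60000 nM. The step that the limit leaves unreadable from compound 2 to compound 3 is expected to stay within the scatter.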

Compound 3, half-maximal cytotoxic concentration: > 25000 nM
Compound 3: no number, only a limit; the forecaster's own chance of this, stated with the estimate: 80%; the middle value is on the limit's open side.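

Within the data shown here, compound 3, like compound 1 and compound 2, gives only a limit in this assay, so no step among the three can be read: the limit of > 25000 nM in this assay, at which 3 of the 3 values shown sit. The compounds shown leave open whether any substituent at this place gives a readable cytotoxic concentration, and how hydroxy, cyano and trifluoromethyl compare.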